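The source may hold more compounds than are shown below. What is called first, only, known or untested is meant among the compounds shown, and "the series" means these compounds.

Measured in an ADME assay on microsomes from liver (Rattus norvegicus) for metabolic stability, read by LC-MS, with a stated time of 10 min, tested at 0.5 uM; a lower number here means that less of the compound is left, a higher number that more of the compound is left:
- compound 1 `c1ccc2c(c1)CN[C@@H](CN(CC[C@@H]1CCCNC1)[C@H]1CCCc3cccnc31)C2`: 28%
- compound 2 `c1ccc2c(c1)CN[C@@H](CN(CCN1CCNCC1)[C@H]1CCCc3cccnc31)C2`: 62%

Compound 2 holds the higher of the two numbers in this assay, at 62%. Compound 3 `c1ccc2c(c1)CN[C@@H](CN(CCCCN1CCNCC1)[C@H]1CCCc3cccnc31)C2` differs from it as follows: 2-(piperazin-1-yl)ethyl in place of piperazin-1-yl on a saturated chain carbon, two bonds along the chain from an amine nitrogen. In words, 2-(piperazin-1-yl)ethyl stands in place of piperazin-1-yl on a saturated chain carbon, two bonds along the chain from an amine nitrogen.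

Among the compounds with values here, only one measured step bears on this, and only indirectly: a number 34 percentage points higher from compound 1 to compound 2 (beyond the scatter). It is large and falls at the same place, but it swaps the ring and leaves the chain length unchanged. Within the data shown here, no measured step covers chain extension, so its size is uncertain. The expected change is a number 14 percentage points lower from compound 2 to compound 3 (beyond the scatter), a moderate fall that would be smaller than the measured step. For compound 3 the estimate is 48%, with an expected range of 26% to 70%.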

Compound 3, percent of the compound remaining: 15%
Estimate against measurement, compound 3: 33 percentage points above, outside the stated range (below it).
By their numbers in this assay, from the lowest: compound 3; then compound 1; then compound 2.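

In this assay, the position on a saturated chain carbon, two bonds along the chain from an amine nitrogen, responds to the length of the group as well as to the identity of its ring: with the piperazin-1-yl ring kept, 2-(piperazin-1-yl)ethyl in place of piperazin-1-yl gives a number 47 percentage points lower from compound 2 to compound 3 (beyond the scatter). The piperazin-1-yl ring alone therefore does not secure a high number, and the extended group also compares poorly with piperidin-3-yl, with a number 13 percentage points lower from compound 1 to compound 3 (beyond the scatter). No measured evidence accounts for either step.

The compounds shown leave open whether a longer chain carrying piperazin-1-yl would lower the number further or leave it unchanged. From the compounds shown here alone, it also remains open whether morpholin-4-yl at this position would follow piperazin-1-yl or piperidin-3-yl.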